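Thiophen-2-yl for Furan-2-yl: Toxicity Expected to Stay Low

The compounds below may be only part of what the source reports. "The series", "measured", "known", "first", "only" and "open" are said of these compounds alone.

The study measures how much each compound harms cultured cells in a toxicity assay on Huh-7 cells (Homo sapiens) for cytotoxicity, with a stated time of 3 days; on this read-out lower numbers stand for higher toxicity in this test and higher numbers for lower toxicity in this test. Of the compounds shown here, three have been measured. Compound 1 `COc1ccc(-c2cn([C@@H]3O[C@H](CO)[C@@H](O)[C@@]3(C)O)c3ncnc(N)c23)cc1` reaches only the limit of the assay: in this assay compound 1 gives > 44000 nM. Compound 2 `C[C@@]1(O)[C@H](O)[C@@H](CO)O[C@H]1n1cc(-c2ccsc2)c2c(N)ncnc21` reaches the same limit, and in this assay compound 2 gives > 44000 nM. The move from compound 1 to compound 2, with thiophen-3-yl in place of 4-methoxyphenyl on an aromatic carbon, is a step that the two limits leave unreadable from compound 1 to compound 2. Compound 3 `Nc1ncnc2c1c(-c1ccco1)cn2[C@H]1C[C@H](O)[C@@H](CO)O1` also returns only a limit, and in this assay compound 3 gives > 44000 nM. Among the measured compounds shown here, compound 3 therefore stands at the same limit as the other two, as the single piece of evidence shows: the limit of > 44000 nM in this assay, at which 3 of the 3 values shown sit.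

Compound 4 `Nc1ncnc2c1c(-c1cccs1)cn2[C@H]1C[C@H](O)[C@@H](CO)O1` has not been measured. It differs from compound 3 by thiophen-2-yl in place of furan-2-yl on an aromatic carbon.

For the measured compounds named here, no measured step bears directly on this change; the only step recorded, from compound 1 to compound 2, is itself unreadable because both ends sit at the limit. Going by the values given here, with every value so far at the limit, the step from compound 3 to compound 4 is expected to be a step that the limit leaves unreadable from compound 3 to compound 4, meaning no change beyond the scatter. Compound 4 is therefore estimated at 60000 nM, with a range from 20000 nM to 200000 nM, most probably reported again as a limit.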

Compound 4, half-maximal cytotoxic concentration: > 44000 nM
Compound 4: only a limit was reported (the forecaster's own chance of this, stated with the estimate: 85%); the middle value is on the limit's open side.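

Compound 3 and compound 4 both return only a limit in this assay, so the step between them, thiophen-2-yl in place of furan-2-yl, cannot be read. The compounds shown leave open at what concentration, if any, each one would harm the cells, and the only evidence is a shared limit: the limit of > 44000 nM in this assay, at which 4 of the 4 values shown sit.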